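The compounds below may be only part of what the source reports. "The series", "measured", "known", "first", "only" and "open" are said of these compounds alone.

The series shares one core, shown in compound 1 `CCN(C)C(=O)/C=C1\CCc2c(F)cc(F)cc21`, which in a functional assay on the whole organism with Mus musculus as the target (on this read-out higher numbers stand for an effect only at larger amounts of compound and lower numbers for an effect already at smaller amounts), gives 56 mg/kg. Compound 2 `O=C(/C=C1\CCc2c(F)cc(F)cc21)NCCO`, carrying a (2-hydroxyethyl)amino group on the carbonyl carbon, gives 100 mg/kg in this assay. Compound 3 `O=C(/C=C1\CCc2c(F)ccc(F)c21)NC1CC1`, with a differently placed pair of fluorines, gives 59 mg/kg. Among the measured compounds shown here, the step of a 1.8-fold higher number from compound 1 to compound 2 (0.25 log units; within the scatter) is the only one-point comparison among the measured compounds, and it stays within the scatter; compound 2 sits at the upper edge of the three numbers, yet its distance to compound 1 and to compound 3 is in each case within the scatter as well.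

Compound 4 `CC(C)NC(=O)/C=C1\CCc2c(F)cc(F)cc21` differs from compound 2 by isopropyl in place of 2-hydroxyethyl on an amide-type nitrogen. For the measured compounds named here, the only step bearing on this change, from compound 1 to compound 2, was within the scatter, and compound 1 and compound 3, both without a hydroxyl on the amide nitrogen, give numbers close to each other. Compound 4 is therefore expected to show a 1.7-fold lower number from compound 2 to compound 4 (0.22 log units; within the scatter), a step no larger than the scatter. The estimate for compound 4 in this assay is 60 mg/kg, with a range from 30 mg/kg to 130 mg/kg.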

Compound 4, dose for half-maximal effect: 50 mg/kg
Beside the measured number, compound 4's estimate is 1.2-fold (0.08 log units) above it, within the range that was stated.
By their numbers in this assay, from the lowest: compounds 4, 1, 3 and 2 (each within the scatter of the next).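

On the amide-type nitrogen of the shared core, isopropyl in place of 2-hydroxyethyl gives a 2.0-fold lower number from compound 2 to compound 4 (0.30 log units; within the scatter) in this assay. Isopropyl has 0 hydrogen-bond donors and 0 hydrogen-bond acceptors where 2-hydroxyethyl has 1 of each, so this change shows that in this small set, a group without either can stand here and the number stays within the scatter. The isopropylamino group of compound 4 also compares with the ethyl(methyl)amino group of compound 1 as a 1.1-fold lower number from compound 1 to compound 4 (0.05 log units; within the scatter), so the three groups compared on this core, in compounds 1, 2 and 4, cannot be told apart in this assay.

As far as these compounds go, whether an aminoethyl group, a carboxymethyl group or a longer chain on this nitrogen would carry the number beyond the scatter remains open. No evidence is available that bears on what lies behind these numbers.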